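Shortening the Aryl Group on the Glycoside Oxygen

This account rests on a few compounds, and the source may have more. Where it says the series, first, only, none or still open, it means among the compounds named here.

Four glycosides built on one shared core are compared in a functional assay on RAW264.7 cells (Mus musculus) for inhibition, read by Griess assay, with a stated time of 24 h; a higher number here means a weaker inhibitor, a lower number a stronger inhibitor. Compound 1 `C/C=C1/[C@H](O[C@@H]2O[C@H](CO)[C@@H](O)[C@H](O)[C@H]2O)OC=C(C(=O)OC)[C@H]1CC(=O)OC[C@H]1O[C@@H](OCCc2ccccc2)[C@H](O)[C@@H](O)[C@@H]1O` gives 65700 nM in this assay. Compound 2 `C/C=C1/[C@H](O[C@@H]2O[C@H](CO)[C@@H](O)[C@H](O)[C@H]2O)OC=C(C(=O)OC)[C@H]1CC(=O)OC[C@H]1O[C@@H](OCc2ccccc2)[C@H](O)[C@@H](O)[C@@H]1O` gives 32500 nM in this assay, and the step of a 2.0-fold lower number from compound 1 to compound 2 (0.31 log units; beyond the scatter) corresponds to phenyl in place of benzyl on a saturated chain carbon bound to an oxygen on a saturated carbon. Compound 3 `C/C=C1/[C@H](O[C@@H]2O[C@H](CO)[C@@H](O)[C@H](O)[C@H]2O)OC=C(C(=O)OC)[C@H]1CC(=O)OC[C@H]1O[C@@H](Oc2ccc(/C=C/CO)cc2OC)[C@H](O)[C@@H](O)[C@@H]1O` gives in this assay only a limit of the assay, > 80000 nM. Compound 3 thus stands at the limit of > 80000 nM in this assay, at which 1 of the 3 values shown sits. The steps of an at least 1.2-fold higher number from compound 1 to compound 3 (0.08 log units; that floor lies within the scatter) and an at least 2.4-fold higher number from compound 2 to compound 3 (0.39 log units; beyond the scatter) are therefore floors only, each ending at the limit.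

Compound 4 `C/C=C1/[C@H](O[C@@H]2O[C@H](CO)[C@@H](O)[C@H](O)[C@H]2O)OC=C(C(=O)OC)[C@H]1CC(=O)OC[C@H]1O[C@@H](Oc2ccc(O)cc2)[C@H](O)[C@@H](O)[C@@H]1O` has not yet been measured in this assay. It differs from compound 3 by 4-hydroxyphenyl in place of 4-(3-hydroxyprop-1-en-1-yl)-2-methoxyphenyl on an oxygen on a saturated carbon. Within the data shown here, the measured steps that bear on this change are the two that lead into compound 3, an at least 1.2-fold higher number from compound 1 to compound 3 (0.08 log units; that floor lies within the scatter) and an at least 2.4-fold higher number from compound 2 to compound 3 (0.39 log units; beyond the scatter), and both are open-ended, so they show only that the aryl group of compound 3 is at least as weak as the benzyl and phenethyl groups. With all three known values weak and an aryl group kept on the same oxygen, the expected step is an at least 1.1-fold lower number from compound 3 to compound 4 (0.05 log units; that floor lies within the scatter), with no movement beyond the scatter anticipated. Compound 4 is estimated at 70000 nM, within a range from 30000 nM to 160000 nM, with a real chance that the assay again reports only a limit.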

Compound 4, half-maximal inhibitory concentration: 58300 nM
Beside the measured number, compound 4's estimate is 1.2-fold (0.08 log units) above it, and the stated range covers the measured number.
By their numbers in this assay, from the lowest: compounds 2, 4 and 1 (each within the scatter of the next, the first and the last beyond it). At a limit, above all of these: compound 3.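

In this assay, among these compounds, the change from 4-(3-hydroxyprop-1-en-1-yl)-2-methoxyphenyl to 4-hydroxyphenyl on this oxygen gives the first exact number for an aryl group with no chain carbon between ring and oxygen, though the step of an at least 1.3-fold lower number from compound 3 to compound 4 (0.13 log units; that floor lies within the scatter) is a floor and its true size stays unknown. Compound 3 remains a limit of the assay, not a number: the limit of > 80000 nM in this assay, at which 1 of the 4 values shown sits. The smaller aryl group cannot be told apart from either chain-linked group, with a 1.8-fold higher number from compound 2 to compound 4 (0.25 log units; within the scatter) and a 1.1-fold lower number from compound 1 to compound 4 (0.05 log units; within the scatter), so removing the chain carbons from the benzyl and phenethyl groups while keeping a hydroxyl on the ring leaves the number within the scatter of both, even though those two groups differ from each other beyond it.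

What the compounds shown leave open is whether the hydroxyl of the 4-hydroxyphenyl group contributes at all, since they include no plain phenyl on this oxygen and no ring carrying a methoxy group alone. They also leave open whether an amine or a carboxylic acid on this ring would move the number far from this weak range.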